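The source may report more compounds than this note shows. Statements on the series, on what has been measured and on what is new or still open speak of the compounds shown alone.

Three compounds share one core and differ only in the group attached to a carbon with a double bond to nitrogen. Compound 1 `COc1ccc(OC)c(/C=N/NC(=O)Nc2ccc(Oc3ccnc(-c4nncn4CCN(C)C)c3)c(F)c2)c1` carries a 2,5-dimethoxyphenyl there, and in a functional assay on NCI-H460 cells (Homo sapiens) for cytotoxicity, read by MTT assay, with a stated time of 72 h (a lower number here means a stronger inhibitor, a higher number a weaker inhibitor), compound 1 gives 2930 nM. Compound 2 `CN(C)CCn1cnnc1-c1cc(Oc2ccc(NC(=O)N/N=C/c3ccc(O)c(O)c3)cc2F)ccn1` gives 1930 nM, and compound 3 `CN(C)CCn1cnnc1-c1cc(Oc2ccc(NC(=O)N/N=C/c3cc(Br)c(O)c(Br)c3)cc2F)ccn1` gives 3760 nM. Among these three numbers compound 1 holds the second highest, closest to compound 3 and furthest from compound 2, yet every gap stays within the scatter: a 1.5-fold lower number from compound 1 to compound 2 (0.18 log units; within the scatter), a 1.3-fold higher number from compound 1 to compound 3 (0.11 log units; within the scatter) and a 1.9-fold higher number from compound 2 to compound 3 (0.29 log units; within the scatter).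

Compound 4 `CN(C)CCn1cnnc1-c1cc(Oc2ccc(NC(=O)N/N=C/c3c(O)ccc4ccccc34)cc2F)ccn1` is the next member of this set, with 2-hydroxynaphthalen-1-yl in place of 2,5-dimethoxyphenyl on a carbon with a double bond to nitrogen. The measured steps all bear on this change, since each swaps the group at the same place, and none of them moved the number beyond the scatter. A step of the same kind is therefore expected here, with no clear direction, so compound 4 is estimated at 2800 nM (range 1200 nM to 6500 nM). That estimate for compound 4 means a step of a 1.0-fold lower number from compound 1 to compound 4 (0.02 log units; within the scatter).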

Compound 4, half-maximal inhibitory concentration: 890 nM
Estimate against measurement, compound 4: 3.1-fold (0.50 log units) above, and the stated range ends above it.
By their numbers in this assay, from the lowest: compound 4; then compounds 2, 1 and 3 (each within the scatter of the next).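

Within the data shown here, this position can shift the number after all: in this assay, 2-hydroxynaphthalen-1-yl is the first group to stand beyond the scatter of the others, with modest steps against all three (a 3.3-fold lower number from compound 1 to compound 4 (0.52 log units; beyond the scatter); a 2.2-fold lower number from compound 2 to compound 4 (0.34 log units; beyond the scatter); a 4.2-fold lower number from compound 3 to compound 4 (0.63 log units; beyond the scatter)). Among these compounds, it is also the only group here with 2 six-membered aromatic rings of carbon only, whereas a hydroxy group alone does not set it apart, as compound 2 and compound 3 carry hydroxy groups too. Nothing measured here explains why this change lowers the number.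

The compounds shown leave open whether the step follows the extra ring or the hydroxy group on it, a question that plain naphthalen-1-yl or 2-methoxynaphthalen-1-yl would address. They also leave open how an amine or a carboxylic acid on this ring would read.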